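The source may report more compounds than this note shows. Statements on the series, on what has been measured and on what is new or still open speak of the compounds shown alone.

In an ADME assay on the whole organism (plasma, strain 129/SvEvBrd x C57BL/6) for pharmacokinetics, with Mus musculus as the target, at a dose of 10 mg/kg by the oral route (a higher number here means more compound in the circulation at the dose given, a lower number less compound in the circulation), three compounds sharing one core have been measured so far. Compound 1 (`OC[C@@H](O)[C@@H](O)[C@H](O)c1c[nH]c(-c2cscn2)n1`) gives 1570 ng.h/mL and compound 2 (`OC[C@@H](O)[C@@H](O)[C@H](O)c1c[nH]c(-c2cocn2)n1`) gives 868 ng.h/mL on this core. Compound 3 (`OC[C@@H](O)[C@@H](O)[C@H](O)c1c[nH]c(-c2ncc[nH]2)n1`) gives 1500 ng.h/mL and lies within the scatter of both others.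

Compound 4 (`OC[C@@H](O)[C@@H](O)[C@H](O)c1c[nH]c(-c2ncon2)n1`) has 1,2,4-oxadiazol-3-yl in place of the 1H-imidazol-2-yl of compound 3 on an aromatic carbon, between two ring nitrogen atoms (1,2,4-oxadiazol-3-yl in place of 1H-imidazol-2-yl on an aromatic carbon). Three measured exchanges of the ring at this place bear on it: a 1.8-fold lower number from compound 1 to compound 2 (0.26 log units; within the scatter) and a 1.0-fold lower number from compound 1 to compound 3 (0.02 log units; within the scatter) and also a 1.7-fold higher number from compound 2 to compound 3 (0.24 log units; within the scatter) all stay small. On these data alone, no 1,2,4-oxadiazol-3-yl compound has been measured yet, so the ring itself remains untested. As far as these compounds go, no step beyond the scatter is therefore expected in this assay and the direction stays open, with only a slight expected lean to a lower number. The estimate amounts to an expected 1.3-fold lower number from compound 3 to compound 4 (0.12 log units; within the scatter) for this exchange. In this assay compound 4 is estimated at 1150 ng.h/mL with an expected range of 500 ng.h/mL to 2600 ng.h/mL for the measurement.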

Compound 4, area under the concentration-time curve: 820 ng.h/mL
For compound 4 the middle estimate is 1.4-fold (0.15 log units) above the measured one; the range from low to high includes it.
By their numbers in this assay, from the lowest: compounds 4, 2, 3 and 1 (each within the scatter of the next).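

In this assay the 1,2,4-oxadiazol-3-yl ring, with three hetero atoms, stays within the scatter of all three earlier rings at this place (a 1.8-fold lower number from compound 3 to compound 4 (0.26 log units; within the scatter); a 1.1-fold lower number from compound 2 to compound 4 (0.02 log units; within the scatter); a 1.9-fold lower number from compound 1 to compound 4 (0.28 log units; within the scatter)). Exchanging the 1H-imidazol-2-yl, which carries a hydrogen-bond donor, for a ring with 0 hydrogen-bond donors and 3 hydrogen-bond acceptors leaves compound 3 and compound 4 within the scatter of each other. Four five-membered aromatic rings now fit this place with no step beyond the scatter among them.

No evidence on the compounds explains these numbers. Open, on these data alone, is whether a carboxylic acid, an amine or a six-membered pyridine ring at this place, or another group in place of the group of 8 heavy atoms, would give a step beyond the scatter.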